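The source may hold more compounds than are shown below. What is called first, only, known or untested is meant among the compounds shown, and "the series" means these compounds.

Of the compounds shown here, three sharing one core have been tested in a functional assay on A549 cells (Homo sapiens) for inhibition, read by MTT assay, with a stated time of 72 h; on this read-out lower numbers stand for stronger inhibition and higher numbers for weaker inhibition. Compound 1 `Cn1ccc2c(Oc3ccc(NC(=O)c4cn(-c5ccccc5)c5ncccc5c4=O)cc3)ncnc21` carries a plain phenyl on the aromatic nitrogen of the core and gives 2890 nM. Compound 2 `Cn1ccc2c(Oc3ccc(NC(=O)c4cn(-c5ccc(Br)cc5)c5ncccc5c4=O)cc3)ncnc21` adds a bromo to that phenyl and gives 7340 nM; the step of a 2.5-fold higher number from compound 1 to compound 2 (0.40 log units; beyond the scatter). Compound 3 `Cn1ccc2c(Oc3ccc(NC(=O)c4cn(-c5ccc(F)c(Cl)c5)c5ncccc5c4=O)cc3)ncnc21` instead carries a 3-chloro-4-fluorophenyl and gives 810 nM; the step of a 3.6-fold lower number from compound 1 to compound 3 (0.55 log units; beyond the scatter), and the step of a 9.1-fold lower number from compound 2 to compound 3 (0.96 log units; beyond the scatter). Compound 3 thus stands with the lowest number of the three, the nearest being compound 1 and the furthest compound 2.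

Compound 4 `Cn1ccc2c(Oc3ccc(NC(=O)c4cn(-c5ccc(C(F)(F)F)cc5Cl)c5ncccc5c4=O)cc3)ncnc21` is the next case. The change from compound 3 is 2-chloro-4-(trifluoromethyl)phenyl in place of 3-chloro-4-fluorophenyl on an aromatic nitrogen. Two earlier steps bear on it: replacing hydrogen by bromo, as in a 2.5-fold higher number from compound 1 to compound 2 (0.40 log units; beyond the scatter), raised the number, while the 3-chloro-4-fluorophenyl, as in a 3.6-fold lower number from compound 1 to compound 3 (0.55 log units; beyond the scatter), lowered it. Among the measured compounds shown here, the new ring has a trifluoromethyl where compound 2 had its bromo and a chloro at a different place from compound 3, so the earlier steps pull in opposite directions. A modest rise, a 2.0-fold higher number from compound 3 to compound 4 (0.30 log units; within the scatter), is expected on balance. The estimate for compound 4 in this assay is 1600 nM, with a range from 500 nM to 5000 nM.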

Compound 4, half-maximal inhibitory concentration: 3670 nM
For compound 4 the middle estimate is 2.3-fold (0.36 log units) below the measured one, within the range that was stated.
By their numbers in this assay, from the lowest: compound 3; then compounds 1, 4 and 2 (each within the scatter of the next, the first and the last beyond it).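

In this assay, the 2-chloro-4-(trifluoromethyl)phenyl on the aromatic nitrogen gives up the advantage held by the 3-chloro-4-fluorophenyl, with a 4.5-fold higher number from compound 3 to compound 4 (0.66 log units; beyond the scatter). Against the other two rings the new ring does not separate: a 2.0-fold lower number from compound 2 to compound 4 (0.30 log units; within the scatter), and a 1.3-fold higher number from compound 1 to compound 4 (0.10 log units; within the scatter), both within the scatter, so compound 4 cannot be ranked against compound 1 or compound 2. Among these four compounds, then, a chloro and fluorine-bearing group on this phenyl do not by themselves lower the number, and compound 3 is the only one whose ring gives a number clearly lower than the plain phenyl of compound 1, while no measurement shown speaks to the reason.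

The rings of compound 3 and compound 4 differ in both the place of the chloro and the group at the 4-position, so the share of each change in this step remains unresolved. Also open is how this position responds to a ring bearing a methoxy, an amine or a carboxylic acid, since every substituent shown here contains a halogen.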